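Adding a hydroxy group to compound 2

The source may report more compounds than this note shows. Statements on the series, on what has been measured and on what is new or still open speak of the compounds shown alone.

In a functional assay on H184B5F5/M10 cells (Homo sapiens) for antiproliferative activity, read by MTT assay, with a stated time of 24 h (on this read-out higher numbers stand for weaker inhibition and lower numbers for stronger inhibition), compound 1 `COc1ccc(C(=O)NNC(=O)/C=C/c2ccc(O)cc2)cc1` gives 8440 nM. Compound 2 `O=C(/C=C/c1ccc(O)cc1)NNC(=O)c1ccc(O)cc1` gives > 10000 nM, which is a limit and not a number. Compound 3 `COc1ccc(C(=O)NNC(=O)/C=C/c2ccc(O)c(OC)c2)cc1` gives > 10000 nM, also a limit. Compound 2 therefore has no exact place and sits at the limit of > 10000 nM in this assay, at which 2 of the 3 values shown sit. Compound 4 `O=C(/C=C/c1ccc(O)c(O)c1)NNC(=O)c1ccc(O)cc1` differs from compound 2 by hydroxy in place of hydrogen on an aromatic carbon. Going by the values given here, two measured steps bear on this change. Adding methoxy in place of hydrogen on an aromatic carbon gave an at least 1.1-fold higher number from compound 1 to compound 3 (0.07 log units; that floor lies within the scatter), and exchanging methyl for hydrogen on an oxygen gave an at least 1.1-fold higher number from compound 1 to compound 2 (0.07 log units; that floor lies within the scatter). Both are only floors, so no step beyond the scatter is expected: a step that the limit leaves unreadable from compound 2 to compound 4. The estimate for compound 4 is 11000 nM, within an expected range of 5000 nM to 25000 nM.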

Compound 4, half-maximal inhibitory concentration: 8680 nM
Compound 4: the middle estimate sits 1.3-fold (0.10 log units) above what was measured; the measured number falls inside the stated range.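

Compound 2 has only a limit, > 10000 nM. With hydroxy in place of hydrogen on this aromatic carbon, compound 4 brings the series back to an exact number, showing that this change can give a readable value in this assay. The change gives an at least 1.1-fold lower number from compound 2 to compound 4 (0.06 log units; that floor lies within the scatter), so the data show no step beyond the scatter, though the true size of the step stays hidden behind the limit.

Still open, from the compounds shown here alone, is whether another group at this place, such as an amine or a carboxylic acid, would move the number beyond the scatter.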